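This account rests on a few compounds, and the source may have more. Where it says the series, first, only, none or still open, it means among the compounds named here.

Values so far in a functional assay on A2780 cells (Homo sapiens) for antiproliferative activity, read by fluorescence, with a stated time of 72 h; on this read-out higher numbers stand for weaker inhibition and lower numbers for stronger inhibition 
- compound 1 `CN1CCC(C(=O)N2Cc3c(NC(=O)NCc4ccccc4)n[nH]c3C2(C)C)CC1` gives 2680 nM 
- compound 2 `CC1(C)c2[nH]nc(NC(=O)c3ccc(F)cc3)c2CN1C(=O)C1CCN(C2CC2)CC1` gives 380 nM 
- compound 3 `CC(C)(C)C(=O)N1Cc2c(NC(=O)c3ccc(F)cc3)n[nH]c2C1(C)C` gives 270 nM 

Compound 1 has the highest number of the three, and its gaps to compound 2 and compound 3 both lie beyond the scatter. Compound 4 `CN1CCC(C(=O)N2Cc3c(NC(=O)c4ccc(Cl)cc4)n[nH]c3C2(C)C)CC1` has 4-chlorophenyl in place of benzylamino on a carbonyl carbon. Among the compounds with values here, no measured step makes this exact change. The nearest guides are compound 2 and compound 3, which also carry a phenyl ring on that carbonyl carbon, though with fluorine rather than chlorine. The two differ elsewhere, by tert-butyl in place of 1-cyclopropylpiperidin-4-yl on a carbonyl carbon, and that step is small (a 1.4-fold lower number from compound 2 to compound 3 (0.15 log units; within the scatter)). Swapping fluorine for chlorine has not been tested here, so the range stays wide. A clear drop is therefore expected, with an estimated step of an 8.4-fold lower number from compound 1 to compound 4 (0.92 log units; beyond the scatter). For compound 4 the estimated value is 320 nM, with an expected range of 110 nM to 900 nM.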

Compound 4, half-maximal inhibitory concentration: 120 nM
Estimate against measurement, compound 4: 2.7-fold (0.43 log units) above, and the stated range covers the measured number.
By their numbers in this assay, from the lowest: compound 4; then compounds 3 and 2 (each within the scatter of the next); then compound 1.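

Within this assay the change from benzylamino to 4-chlorophenyl on a carbonyl carbon gives a 22-fold lower number from compound 1 to compound 4 (1.35 log units; beyond the scatter) with the rest of the molecule held the same, so the group at this position clearly matters on this read-out. Both groups carry a six-membered aromatic ring of carbon only, so the ring stays while the benzylamino nitrogen and its hydrogen-bond donor go and a chlorine arrives. No measurement shown explains the size of this step.

The compounds shown do not separate the loss of that nitrogen from the arrival of the chlorine, and a plain phenyl group on the same carbonyl carbon would be needed to pull the two apart. Going by these compounds, whether chlorine differs from fluorine here also stays open, since 4-fluorophenyl appears only in compounds that differ from compound 4 elsewhere too.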